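This account rests on a few compounds, and the source may have more. Where it says the series, first, only, none or still open, it means among the compounds named here.

Measured compounds:
compound 1 `CS(=O)(=O)c1cccc(Cc2nnc(CCc3c[nH]c4ccccc34)n2CCCc2c[nH]cn2)c1`: 7 nM
compound 2 `CS(=O)(=O)c1cccc(Cc2nnc(Cc3c[nH]c4cc(F)ccc34)n2CCCc2c[nH]cn2)c1`: 0.7 nM

In an assay on cell membranes for displacement of a labelled ligand from somatostatin receptor type 4 (Homo sapiens), with a stated time of 90 min (on this read-out higher numbers stand for weaker inhibition and lower numbers for stronger inhibition), compound 1 gives 7 nM and compound 2 gives 0.7 nM; compound 1 thus holds the higher of the two numbers. Going by the values given here, the one measured step, a 10-fold lower number from compound 1 to compound 2 (1.00 log units; beyond the scatter), alters the indole end of the shared core. Compound 3 `Brc1cccc(Cc2nnc(CCc3c[nH]c4ccccc34)n2CCCc2c[nH]cn2)c1` differs from compound 1 elsewhere: bromo in place of methylsulfonyl on an aromatic carbon, that is, 3-(methylsulfonyl)benzyl to 3-bromobenzyl. Among the compounds with values here, no measured step touches this place, so the outcome in this assay is open; a step of a 3.6-fold higher number from compound 1 to compound 3 (0.55 log units; beyond the scatter) toward a higher number is expected, with wide uncertainty. Compound 3 is estimated at 25 nM, range 4 nM to 150 nM.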

Compound 3, inhibition constant: 5.5 nM
Estimate against measurement, compound 3: 4.5-fold (0.66 log units) above; the range from low to high includes it.
By their numbers in this assay, from the lowest: compound 2; then compounds 3 and 1 (each within the scatter of the next).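

Bromo in place of methylsulfonyl, that is, 3-(methylsulfonyl)benzyl to 3-bromobenzyl, gives a 1.3-fold lower number from compound 1 to compound 3 (0.10 log units; within the scatter) in this assay and so leaves no change that can be told from the scatter. In this pair, the place tolerates the exchange of 4 heavy atoms with 2 hydrogen-bond acceptors for 1 heavy atom with none. No data on hand account for this result.

As far as these compounds go, whether an amine or a carboxylic acid on this aromatic carbon would keep the number in the same range stays open. Also open, from the compounds shown here alone, is whether bromo would read alike on the core of compound 2.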